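The source may report more compounds than this note shows. Statements on the series, on what has been measured and on what is new or still open speak of the compounds shown alone.

Notes on the series. Compound 1 `CC(C)c1ccc(Cc2sc3c(c2C(=O)N[C@@H](C)c2ccc(C(=O)O)cc2)CCOC3)cc1` carries a carboxylic acid on the phenyl of the benzylic amide and a 4-isopropylbenzyl group on the shared core. For the measured compounds named here, in a functional assay on CHO/Galpha16 cells for antagonist activity at prostaglandin E2 receptor EP4 subtype (Homo sapiens), read by calcium flux, with a stated time of 15 min (on this read-out lower numbers stand for stronger inhibition and higher numbers for weaker inhibition), compound 1 gives 2.7 nM, the only numerical value in hand for this read-out, so it is the reference point. Compound 2 `COC(=O)c1ccc([C@H](C)NC(=O)c2c(Cc3ccc(F)cc3)sc3c2CCOC3)cc1` differs from compound 1 at two places at once, the methyl ester in place of the acid and the fluorobenzyl group, and in this assay compound 2 gives > 1000 nM, which is a limit of the assay and not a number. Going by the values given here, that limit of > 1000 nM in this assay, at which 1 of the 2 values shown sits, says only that compound 2 is weaker than the range measured; with two changes at once it supports no single step.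

Compound 3 `C[C@H](NC(=O)c1c(C#Cc2ccc(=O)[nH]c2)sc2c1CCOC2)c1ccc(C(=O)O)cc1` keeps the acid and the rest of compound 1 and changes only the substituent on the core: a group of 9 heavy atoms (7 carbon, 1 nitrogen, 1 oxygen; one six-membered aromatic ring with 1 hetero atom) in place of a group of 10 heavy atoms (10 carbon; one six-membered aromatic ring of carbon only), on an aromatic carbon. Among the compounds with values here, no measured step maps onto this exchange. A step from compound 1 to compound 3 that is beyond the scatter and toward weaker inhibition is expected, since compound 1 at 2.7 nM sets a high bar for an aryl group that is replaced, so an 11-fold higher number from compound 1 to compound 3 (1.05 log units; beyond the scatter) is anticipated. For compound 3 in this assay the estimate is 30 nM, with a range from 5 nM to 200 nM.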

Compound 3, half-maximal inhibitory concentration: 642 nM
Beside the measured number, compound 3's estimate is 21-fold (1.33 log units) below it; measured number outside the range, above it.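

For the compounds shown here, with the carboxylic acid and the benzylic amide kept, the exchange of 4-isopropylbenzyl for the group with the triple bond and the six-membered aromatic ring with 1 hetero atom, on the aromatic carbon next to the ring sulfur, gives in this assay a 240-fold higher number from compound 1 to compound 3 (2.38 log units; beyond the scatter), the first step that can be read at a single place. It shows that this position is not indifferent to its substituent and that the carboxylic acid, kept unchanged, does not by itself preserve the strong inhibition of compound 1. Going by these compounds alone, nothing measured so far bears on the cause of this step.

The step covers several differences at once, so a 4-isopropylphenylethynyl group, which would keep the triple bond with the carbon-only ring and the isopropyl, or the ring of compound 3 joined through a single methylene carbon, would be needed to assign it to one part of the exchange. Also open, going by these compounds, is how the methyl ester behaves on its own, since a methyl ester paired with 4-isopropylbenzyl would separate that change from the fluorobenzyl group.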